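The source may hold more compounds than are shown below. What is called first, only, known or untested is meant among the compounds shown, and "the series" means these compounds.

Among the measured compounds shown here, compound 2 `Fc1ccc(/C=N/NC(=S)Nc2cccc3ccccc23)cc1Cl` gives 500 ug/mL in an ADME assay on NIH3T3 cells (Mus musculus) for cytotoxicity, read by XTT assay, with a stated time of 24 h (on this read-out lower numbers stand for stronger inhibition and higher numbers for weaker inhibition), the only numerical value. Compound 1 `Fc1cccc(/C=N/NC(=S)Nc2cccc3ccccc23)c1F` gives > 500 ug/mL in this assay, which is a limit of the assay. The step of a number no higher from compound 1 to compound 2 (the limit leaves the size open) cannot be sized because of the limit of > 500 ug/mL in this assay, at which 1 of the 2 values shown sits. Compound 3 `Fc1cc(F)cc(/C=N/NC(=S)Nc2cccc3ccccc23)c1` carries 3,5-difluorophenyl in place of 3-chloro-4-fluorophenyl on a carbon with a double bond to nitrogen. For the measured compounds named here, the only measured step touching this position is the one from compound 1 to compound 2, and its size stays open. No shift beyond the scatter is therefore expected for compound 3 in this assay. Compound 3 is estimated at 500 ug/mL (range 250 ug/mL to 1000 ug/mL), a step of no change at the digits printed from compound 2 to compound 3 (within the scatter).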

Compound 3, half-maximal inhibitory concentration: > 500 ug/mL
Compound 3 gave a limit, no number; the forecaster's own chance of this, stated with the estimate: 50%; the middle value lies on the limit itself.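

Replacing 3-chloro-4-fluorophenyl with 3,5-difluorophenyl on this carbon gives a number no lower from compound 2 to compound 3 (the limit leaves the size open) in this assay. Among the compounds shown here, compound 2, at 500 ug/mL, remains the only number at this position. Both difluorophenyl compounds now sit at a limit, so the step between compound 1 and compound 3 and the size of each step cannot be read: the limit of > 500 ug/mL in this assay, at which 2 of the 3 values shown sit.

Open, on these data alone, is whether an amine or a carboxylic acid on the phenyl ring in place of the halogens would give a number in this assay. Also open, as far as these compounds go, is how far compound 1 and compound 3 lie from compound 2.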